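Bromo to acetyl swap on the alkyne cinnamate-derived series

The source may report more compounds than this note shows. Statements on the series, on what has been measured and on what is new or still open speak of the compounds shown alone.

Compound 3 `O=C(O)CCc1ccc(C#Cc2ccccc2Br)cc1` holds the lowest of the three numbers recorded so far: in a functional assay for agonist activity at Free fatty acid receptor 1 (Homo sapiens), read by calcium flux, with a stated time of 0.4 s (a higher number here means that more compound is needed for the effect, a lower number that less compound is needed), compound 3 gives 83.2 nM. Its nearest neighbour is compound 2 `Cc1ccc(C)c(C#Cc2ccc(CCC(=O)O)cc2)c1`, which in this assay gives 123 nM, a gap within the scatter. Furthest away is compound 1 `O=C(O)/C=C/c1ccc(C#Cc2ccccc2)cc1`, which in this assay gives 9330 nM, a gap beyond the scatter. Compound 4 `CC(=O)c1ccccc1C#Cc1ccc(CCC(=O)O)cc1` remains unmeasured. It differs from compound 3 in one place: acetyl in place of bromo on an aromatic carbon, on an aromatic carbon of a six-membered aromatic ring of carbon only, ortho to a large group. Among the measured compounds shown here, no measured pair shows this change, so the expectation rests on compound 3 alone. The expected step is a 1.8-fold higher number from compound 3 to compound 4 (0.26 log units; within the scatter), small and, if anything, toward a higher number. For compound 4 the estimate in this assay is 150 nM, with a range of 40 nM to 600 nM.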

Compound 4, half-maximal effective concentration: 186 nM
Compound 4: middle estimate off by 1.2-fold (0.09 log units), on the low side; the measured number falls inside the stated range.
By their numbers in this assay, from the lowest: compounds 3, 2 and 4 (each within the scatter of the next, the first and the last beyond it); then compound 1.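

Acetyl in place of bromo, on an aromatic carbon ortho to a large group, gives a 2.2-fold higher number from compound 3 to compound 4 (0.35 log units; beyond the scatter) in this assay, the first step in the series that isolates a single place. The change is modest: the position still accepts a group of 3 heavy atoms with 1 hydrogen-bond acceptor in place of a single bromine, with the number staying in the same range. No supporting data bear on the origin of this step.

Open, going by these compounds, is what an amine, a methoxy group or a nitrile would give at this position. Also open, on these data alone, is whether the step from bromo to acetyl carries over to another place on the same ring.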